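The source may report more compounds than this note shows. Statements on the series, on what has been measured and on what is new or still open speak of the compounds shown alone.

Compound 1 `Oc1ccccc1CNc1ccc(N2CCNCC2)cc1` is reported as "not active" (no number reported) in a functional assay on Jurkat cells (Homo sapiens) for activation, with a stated time of 24 h (on this read-out lower numbers stand for an effect already at smaller amounts and higher numbers for an effect only at larger amounts of compound), without a number. In this assay compound 2 `Oc1ccccc1CNc1ccc(-c2ccccc2F)cc1` gives 2150 nM, the only number shown for these two compounds, so it stands alone as the reference point. Compound 3 `Cc1ccccc1-c1ccc(NCc2ccccc2O)cc1` differs from compound 2 by methyl in place of fluoro on an aromatic carbon, ortho to a large group. Going by the values given here, no measured step of this kind exists here, so a step of a 1.1-fold lower number from compound 2 to compound 3 (0.03 log units; within the scatter) is expected, essentially none beyond the usual scatter in either direction. Compound 3 is therefore estimated at 2000 nM, between 800 nM and 5000 nM.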

Compound 3, half-maximal effective concentration: 5220 nM
Beside the measured number, compound 3's estimate is 2.6-fold (0.42 log units) below it, outside the stated range (above it).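

In this assay, methyl in place of fluoro on an aromatic carbon, ortho to a large group, gives a 2.4-fold higher number from compound 2 to compound 3 (0.39 log units; beyond the scatter). Going by these compounds alone, this position therefore responds to even this small exchange, which the earlier compounds, with only one number between them, could not show. Nothing available accounts for the step. Still open, on these data alone, is how a chloro or methoxy group would read at this place, and whether an amine or a carboxylic acid there would carry the number further in either direction.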